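The source may hold more compounds than are shown below. What is called first, only, known or untested is meant among the compounds shown, and "the series" means these compounds.

Three compounds with a shared core carrying two trifluoromethyl groups have been measured in an ADME assay for pharmacokinetics, read by LC-MS, in phosphate buffer, with a stated time of 72 h, at pH 7.4, tested at 250 uM; a higher number here means that the compound lasts longer, a lower number that the compound disappears faster. Compound 1 `C=CC(=O)Oc1cc(C(F)(F)F)cc(C(F)(F)F)c1` gives < 0.017 h in this assay, which is a limit of the assay rather than a number. Compound 2 `C=CS(=O)(=O)c1cc(C(F)(F)F)cc(C(F)(F)F)c1` likewise gives < 0.017 h, also a limit. Among the compounds with values here, compound 3 `C#Cc1cc(C(F)(F)F)cc(C(F)(F)F)c1` gives 0.3 h, the only actual number among the three; the step of an at least 17-fold higher number from compound 1 to compound 3 (1.24 log units; beyond the scatter) and the step of an at least 17-fold higher number from compound 2 to compound 3 (1.24 log units; beyond the scatter) are both large, while the step that the two limits leave unreadable from compound 1 to compound 2 cannot be read because of the limit of < 0.017 h in this assay, at which 2 of the 3 values shown sit.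

Compound 4 `FC(F)(F)c1cc(C2CO2)cc(C(F)(F)F)c1` has not yet been measured. It differs from compound 3 in one place: oxiran-2-yl in place of ethynyl on an aromatic carbon. Within the data shown here, none of the measured steps involves an oxiran-2-yl group, so the steps to compound 3 only show that a change at this position can move the half-life by a large amount; they do not say in which direction the present change will go. The expectation is therefore broad: the step of a 13-fold higher number from compound 3 to compound 4 (1.12 log units; beyond the scatter) is estimated to be an increase, but with wide uncertainty. Compound 4 is expected to give about 4 h in this assay, within a range from 0.3 h to 48 h.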

Compound 4, half-life: > 50 h
Compound 4: a limit, no number (the forecaster's own chance of this, stated with the estimate: 15%); at least 12-fold (1.09 log units) between middle value and limit.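

In this assay, this aromatic carbon had so far shown only that ethynyl outlasts vinylsulfonyl and (vinylcarbonyl)oxy, and the oxiran-2-yl group now extends that range far upward, with an at least 160-fold higher number from compound 3 to compound 4 (2.22 log units; beyond the scatter). Measured against the two groups at the short-lived end, the distance is wider still, with an at least 2900-fold higher number from compound 2 to compound 4 (3.46 log units; beyond the scatter) and an at least 2900-fold higher number from compound 1 to compound 4 (3.46 log units; beyond the scatter), so a single change at this one place spans nearly the whole range that this assay can read. Compound 4 gives > 50 h, which is a limit and not a number, and each of these three steps is therefore only a minimum size, because the true half-life of compound 4 lies beyond what was read: the limit of > 50 h in this assay, at which 1 of the 4 values shown sits.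

The compounds shown cannot separate the contribution of the three-membered ring from that of its oxygen, and a cyclopropyl group on the same aromatic carbon would test this directly. They also say nothing about how an amine or a longer chain would behave at this place, or about the part played by the two trifluoromethyl groups, which are present in all four compounds.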